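The compounds below may be only part of what the source reports. "The series", "measured", "known", "first", "only" and "open" are said of these compounds alone.

Compound 1 `O=C(/C(=C\c1ccc([N+](=O)[O-])c(O)c1)SCc1ccc(Br)cc1)c1cc(Cl)ccc1O` gives 10000 nM in a functional assay on DU-145 cells (Homo sapiens) for inhibition, read by trypan blue exclusion, with a stated time of 96 h; on this read-out lower numbers stand for stronger inhibition of growth and higher numbers for weaker inhibition of growth.
Compound 2 `O=C(/C(=C\c1ccc(F)cc1C(F)(F)F)[S+]([O-])Cc1ccc(Cl)cc1)c1ccc(Cl)cc1` gives 50000 nM in this assay.

Of the two measured compounds, compound 1 shows the lower number in this assay; compound 2 gives a higher number, and the gap between them lies beyond the usual scatter. Compound 3 `O=C(/C(=C\c1ccc([N+](=O)[O-])c(O)c1)SCc1ccc(Br)cc1)c1ccc(C(F)(F)F)cc1` has not yet been measured. It differs from compound 1 in one place: 4-(trifluoromethyl)phenyl in place of 5-chloro-2-hydroxyphenyl on a carbonyl carbon. Among the measured compounds shown here, no directly comparable step between measured compounds exists for this change, so the step from compound 1 to compound 3 is expected to be small, a 1.5-fold higher number from compound 1 to compound 3 (0.18 log units; within the scatter), with a modest lean toward a higher number. Compound 3 is therefore estimated at 15000 nM, within a range from 5000 nM to 50000 nM.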

Compound 3, concentration for 50% growth inhibition: 1000 nM
Compound 3: the middle estimate sits 15-fold (1.18 log units) above what was measured, outside the stated range (below it).
By their numbers in this assay, from the lowest: compound 3; then compound 1; then compound 2.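

The group on the carbonyl carbon strongly affects growth inhibition in this assay: replacing 5-chloro-2-hydroxyphenyl with 4-(trifluoromethyl)phenyl gives a 10-fold lower number from compound 1 to compound 3 (1.00 log units; beyond the scatter) on the otherwise unchanged core of compound 1. Activity at this position therefore does not require the hydrogen-bond donor of the leaving group, since compound 3 has none there. Nothing measured here accounts for the size of this step.

The compounds shown do not separate the loss of the hydroxyl and chlorine from the gain of trifluoromethyl. Going by these compounds, how an amine or a carboxylic acid on this phenyl ring would behave remains open.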